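Removing one double bond from a long chain

A few compounds are considered here, and "the series" means these few. Any claim that something is new, unique, unknown or untested is made for them only; others in the source may bear on it.

Measured in a functional assay on MDA-MB-231 cells (Homo sapiens) for antiproliferative activity, read by MTT assay; a higher number here means a weaker inhibitor, a lower number a stronger inhibitor
Compound 1 `CCCC/C=C\CCCCCCCCCC1(O)CC(=O)c2c(O)cc(OCOC)cc2O1` gives 42800 nM
Compound 2 `CCCCC/C=C\C/C=C\CCCCCCCc1cc(=O)c2c(O)c(C)c(OCOC)cc2o1` gives > 87000 nM as a limit of the assay

For the measured compounds named here, compound 1 holds the only actual number in this assay so far. The result for compound 2 is only a limit.

Compound 3 `CCCCCCCCCCCCCCCC1(O)CC(=O)c2c(O)cc(OCOC)cc2O1` keeps the core of compound 1 and alters only the long chain (hexyl in place of hex-1-en-1-yl on a saturated chain carbon, nine bonds along the chain from a saturated ring carbon). The double bond in that chain is therefore gone, while the chain itself remains in place. Going by the values given here, no pair of measured compounds shows this kind of change, so the expectation has only one anchor. Starting from compound 1 at 42800 nM no shift beyond the usual scatter is expected, in either direction. The expected change (a 1.1-fold higher number from compound 1 to compound 3 (0.02 log units; within the scatter)) is therefore small. Compound 3 is estimated at 45000 nM with an expected range from 22000 nM to 90000 nM in this measurement.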

Compound 3, half-maximal inhibitory concentration: > 87000 nM
Compound 3 ended at the assay's limit (the forecaster's own chance of this, stated with the estimate: 20%); at least 1.9-fold (0.28 log units) between middle value and limit.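

For the compounds shown here, compound 1 and compound 3 are the first pair here that differ in one place, so this is the first direct look at the double bond in the long chain. In this assay, compound 3 gives > 87000 nM, which is a limit and not a number. Replacing hex-1-en-1-yl with hexyl therefore gives an at least 2.0-fold higher number from compound 1 to compound 3 (0.30 log units; that floor lies within the scatter), and the true size of this step stays unknown because the reading stops at a limit: the limit of > 87000 nM in this assay, at which 2 of the 3 values shown sit.

As far as these compounds go, it remains open whether an exact value for compound 3 would lie beyond the usual scatter from compound 1. Also open, from the compounds shown here alone, is how a longer chain, or an amine or a carboxylic acid in place of hexyl, would read in this assay.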